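Sulfonamide nitrogen swap in the series

The compounds below may be only part of what the source reports. "The series", "measured", "known", "first", "only" and "open" are said of these compounds alone.

Two members of the series have been measured so far. In a functional assay on K562 cells (Homo sapiens) for inhibition, read by CCK-8 assay, with a stated time of 72 h (a higher number here means a weaker inhibitor, a lower number a stronger inhibitor), compound 1 `O=C(/C=C/c1cccnc1)NCCCCc1ccc(S(=O)(=O)Nc2ccccc2)cc1` reads 9.56 nM and compound 2 `Cc1cccc(NS(=O)(=O)c2cccc(CCCCCCNC(=O)/C=C/c3cccnc3)c2)c1` reads 4.78 nM as its value. These two numbers lie within the scatter of each other, so compound 2 stands level with compound 1 and the pair cannot be ranked. Within the data shown here, no measured step exists between compounds that differ in one place only.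

The next member is compound 3 `O=C(/C=C/c1cccnc1)NCCCCCCc1cccc(S(=O)(=O)Nc2ccc(F)cc2)c1`, still to be measured in this assay. It carries 4-fluorophenyl in place of 3-methylphenyl on a sulfonamide nitrogen and otherwise matches compound 2.

Among the measured compounds shown here, with no step to draw on, the closest guide is the value of compound 2 at 4.78 nM in the same assay. No change in either direction is expected beyond the scatter. The estimated change a 1.0-fold higher number from compound 2 to compound 3 (0.02 log units; within the scatter) is expected to stay small, with no direction favoured. The estimated value for compound 3 is 5 nM with an expected range of 1.8 nM to 14 nM for this measurement.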

Compound 3, half-maximal inhibitory concentration: 0.93 nM
For compound 3 the middle estimate is 5.4-fold (0.73 log units) above the measured one, outside the stated range (below it).
By their numbers in this assay, from the lowest: compound 3; then compounds 2 and 1 (each within the scatter of the next).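

Read in this assay the exchange of 3-methylphenyl for 4-fluorophenyl on a sulfonamide nitrogen gives a 5.1-fold lower number from compound 2 to compound 3 (0.71 log units; beyond the scatter) as the only single-place step in the series, and it shows that the aryl group at this position can shift the read-out beyond the scatter, though modestly. The shift comes with no change in the counted features: the two groups match in heavy-atom count, in the six-membered aromatic ring of carbon, in hydrogen-bond donors and acceptors, and in net charge, and differ only in the substituent and its ring position as their names give them. No measured information on any property of these groups accompanies the step, so the data offer no explanation for it.

The compounds shown do not separate the swap of methyl for fluorine from the move of the substituent on the ring, a question that a 3-fluorophenyl or a 4-methylphenyl group on the same nitrogen would address. On these data alone, how far the position tolerates other kinds of group, such as a 4-chlorophenyl, a pyridine ring or an aryl group bearing a carboxylic acid, also stays open.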